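Shortening an Ethoxy Group: Expected Effect on Cell Growth

The source may report more compounds than this note shows. Statements on the series, on what has been measured and on what is new or still open speak of the compounds shown alone.

Measured compounds:
compound 1 `Cc1ccc2nc(C(=O)Nc3c(F)cc(-c4cccc(F)c4)cc3F)c(C)c(C(=O)O)c2c1`: 15.2%
compound 2 `CCc1ccc2nc(C(=O)Nc3c(F)cc(-c4cccc(F)c4)cc3F)c(C)c(C(=O)O)c2c1`: 1.68%
compound 3 `CCOc1ccc2nc(C(=O)Nc3c(F)cc(-c4cccc(F)c4)cc3F)c(C)c(C(=O)O)c2c1`: 5.34%

In a functional assay on Hep 3B2 cells (Homo sapiens) for antiproliferative activity, read by MTT assay, with a stated time of 24 h, tested at 0.41 ug/mL (a lower number here means a weaker effect, a higher number a stronger effect of the compound at the concentration tested), compound 3 gives 5.34%, the second highest of the three numbers; its gaps to the others, a number 3.7 percentage points higher from compound 2 to compound 3 (within the scatter) and a number 9.9 percentage points lower from compound 1 to compound 3 (within the scatter), both lie within the scatter. Compound 4 `COc1ccc2nc(C(=O)Nc3c(F)cc(-c4cccc(F)c4)cc3F)c(C)c(C(=O)O)c2c1` differs from compound 3 by hydrogen in place of methyl on a saturated chain carbon bound to an oxygen on an aromatic ring. Within the data shown here, the only measured step that adds or removes a chain carbon is a number 13.5 percentage points lower from compound 1 to compound 2 (beyond the scatter), where a carbon entering on a saturated chain carbon bound to an aromatic carbon lowered the number. Here a carbon leaves, on a chain bound to an oxygen, so at most a small rise is expected, likely within the scatter. Compound 4 is therefore estimated at 9%, between -4% and 22%, a step of a number 3.7 percentage points higher from compound 3 to compound 4 (within the scatter).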

Compound 4, a percentage reported as inhibition, at one concentration (the size of the read-out at that concentration, not a potency): 0.68%
Beside the measured number, compound 4's estimate is 8.3 percentage points above it; the measured number falls inside the stated range.
By their numbers in this assay, from the lowest: compounds 4, 2, 3 and 1 (each within the scatter of the next, the first and the last beyond it).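

In this assay, shortening ethoxy to methoxy gives a number 4.7 percentage points lower from compound 3 to compound 4 (within the scatter), and methoxy in place of ethyl on the aromatic carbon gives a number 1 percentage points lower from compound 2 to compound 4 (within the scatter). Only methoxy in place of methyl gives a step of note, a number 14.5 percentage points lower from compound 1 to compound 4 (beyond the scatter), so at this position methoxy, like ethyl, separates from methyl. Removing or adding one chain carbon therefore does not act alike on the chain bound to the aromatic carbon and the chain bound to oxygen: the same change on two cores in this assay, a number 13.5 percentage points lower (beyond the scatter) from compound 1 to compound 2 and a number 4.7 percentage points higher (within the scatter) from compound 4 to compound 3, 18.2 percentage points apart, beyond the scatter of two such steps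

The compounds shown leave open how a longer chain, such as propoxy, or an amine on this aromatic carbon would read. They also leave open whether any group there could exceed the value of compound 1.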